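This account rests on a few compounds, and the source may have more. Where it says the series, first, only, none or still open, it means among the compounds named here.

Measured compounds:
compound 1, `CCCc1cn([C@@H]2O[C@@H]3CO[PH](O)(O)O[C@H]3[C@H]2O)c(=O)nc1N`: in a functional assay on L1210 cells (Mus musculus) for cytotoxicity (a higher number here means a weaker inhibitor, a lower number a stronger inhibitor), compound 1 gives > 200 ug/mL
compound 2, `Cc1cn([C@@H]2O[C@@H]3COP(=O)(O)O[C@H]3[C@H]2O)c(=O)nc1N`: in this assay compound 2 gives > 200 ug/mL

Neither reading is a number. For compound 1 the value > 200 ug/mL is a limit of the assay. For compound 2 the value > 200 ug/mL is likewise a limit of the assay. Compound 2 thus stands at the limit of > 200 ug/mL in this assay, at which 2 of the 2 values shown sit, and on the numbers shown nothing separates it from compound 1; no step between the two measured compounds is given.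

Compound 3, `CC(C)c1cn([C@@H]2O[C@@H]3COP(=O)(O)O[C@H]3[C@H]2O)c(=O)nc1N`, has not been measured in this assay. Its change from compound 2 is isopropyl in place of methyl on an aromatic carbon. Among the compounds with values here, with both measured values sitting at the same limit (the limit of > 200 ug/mL in this assay, at which 2 of the 2 values shown sit), there is no measured step from which to size this change.

The expectation for compound 3 in this assay is no step beyond the scatter, with the reading most likely remaining a limit. Compound 3 is estimated at 200 ug/mL, within a range of 100 ug/mL to 400 ug/mL. The step this estimate means is a number no higher from compound 2 to compound 3 (the limit leaves the size open), expected to be essentially none.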

Compound 3, concentration for 50% inhibition: > 200 ug/mL
Compound 3 was reported as a limit (the forecaster's own chance of this, stated with the estimate: 85%); the middle value lies on the limit itself.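

No step can be read from compound 2 to compound 3 for isopropyl in place of methyl in this assay, because both readings are limits of the assay and not numbers: the limit of > 200 ug/mL in this assay, at which 3 of the 3 values shown sit.

The compounds shown leave open whether any change on this aromatic carbon gives a numerical reading in this assay.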